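This account rests on a few compounds, and the source may have more. Where it says the series, first, only, none or still open, it means among the compounds named here.

Values in an ADME assay on MDBK cells (Bos taurus) for cytotoxicity, read by MTT assay, with a stated time of 96 h; a lower number here means that less compound is tolerated, a higher number that more compound is tolerated:
- compound 1 `FC(F)(F)c1cccc(NC(=S)Nc2ccc(I)cc2)c1`: 9500 nM
- compound 2 `Fc1cccc(NC(=S)Nc2cccc(C(F)(F)F)c2)c1`: 10000 nM

Compound 2 gives 10000 nM, within the scatter of compound 1. Compound 3 `FC(F)(F)c1cccc(NC(=S)Nc2ccccc2Br)c1` is not yet measured. It differs from compound 2 as follows: 2-bromophenyl in place of 3-fluorophenyl on an amide-type nitrogen. In short, 2-bromophenyl stands in place of 3-fluorophenyl on an amide-type nitrogen.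

Within the data shown here, the only measured step, a 1.1-fold higher number from compound 1 to compound 2 (0.02 log units; within the scatter), also exchanges the group at this place, and it stays within the scatter. On that single step, no change beyond the scatter is expected in this assay. The expected step is a 1.2-fold higher number from compound 2 to compound 3 (0.08 log units; within the scatter). For compound 3 the estimate is 12000 nM, with an expected range of 4500 nM to 35000 nM.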

Compound 3, half-maximal cytotoxic concentration: > 100000 nM
Compound 3: no number, only a limit; the forecaster's own chance of this, stated with the estimate: 15%; middle value at least 8.3-fold (0.92 log units) away from the limit.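

In this assay, the aryl group at this place on the amide-type nitrogen turns out to matter: 2-bromophenyl gives a clear shift (an at least 10-fold higher number from compound 2 to compound 3 (1.00 log units; beyond the scatter)) and (an at least 10-fold higher number from compound 1 to compound 3 (1.02 log units; beyond the scatter)). The earlier exchange of 4-iodophenyl for 3-fluorophenyl stayed within the scatter (a 1.1-fold higher number from compound 1 to compound 2 (0.02 log units; within the scatter)). As far as these compounds go, compound 3 reads (> 100000 nM), which is a limit and not a number, so the full size of both steps stays unknown.

The compounds shown do not separate the effect of bromine from that of its location in 2-bromophenyl. From the compounds shown here alone, how 2-chlorophenyl or 2-aminophenyl would read at this place remains open.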